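The source may hold more compounds than are shown below. What is called first, only, known or untested is meant among the compounds shown, and "the series" means these compounds.

Among the measured compounds shown here, in a functional assay on A-375 cells (Homo sapiens) for inhibition, read by CCK-8 assay, with a stated time of 72 h, tested at 8 uM (on this read-out higher numbers stand for more inhibition of growth at the one concentration tested and lower numbers for less inhibition of growth), compound 1 `COc1ccc(SCc2ccc(/C=C/C(=O)Nc3ccccc3N)cc2)cc1OC` gives 46.4%, while compound 2 `Cc1cc(C)cc(SCc2ccc(/C=C/C(=O)Nc3ccccc3N)cc2)c1` gives 2.49%, the lower of the two numbers so far. These two compounds differ only in the group on the sulfur, and a number 43.9 percentage points lower from compound 1 to compound 2 (beyond the scatter) shows a large change, well beyond the usual scatter. Compound 3 `Nc1ccccc1NC(=O)/C=C/c1ccc(CSc2cccc(F)c2)cc1` keeps the shared core and changes that same place: 3-fluorophenyl in place of 3,5-dimethylphenyl on a sulfur. For the measured compounds named here, that single step is the only measured evidence, and it shows that a swap here can move the number a long way. Going by the values given here, no measured compound carries the 3-fluorophenyl group, so the direction remains uncertain. Compound 2, at 2.49%, has little room left to fall, so a moderate rise is expected, with a number 19.5 percentage points higher from compound 2 to compound 3 (beyond the scatter) as the estimated step. The estimate for compound 3 is 22%, with an expected range from 3% to 50%.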

Compound 3, percent growth inhibition at one concentration: 9.08%
Compound 3: the middle estimate sits 12.9 percentage points above what was measured, and the stated range covers the measured number.
By their numbers in this assay, from the lowest: compounds 2 and 3 (each within the scatter of the next); then compound 1.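

With 3-fluorophenyl in place of 3,5-dimethylphenyl on the sulfur, this assay shows a number 6.6 percentage points higher from compound 2 to compound 3 (within the scatter) and so does not separate these two groups. Set against the 3,4-dimethoxyphenyl group, the same 3-fluorophenyl group gives a number 37.3 percentage points lower from compound 1 to compound 3 (beyond the scatter) and so the large drop seen earlier is not particular to 3,5-dimethylphenyl. Among the compounds shown here, two quite different groups on this sulfur now stand far under compound 1, which makes 3,4-dimethoxyphenyl the one group of the three that stands apart at this position.

From the compounds shown here alone, it remains open whether a single methoxy group on the phenyl ring would hold the higher number, or whether both methoxy groups are needed, and how an amine or a carboxylic acid on that ring would read. Nothing measured here explains why the 3,4-dimethoxyphenyl group stands apart.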